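Swapping a Methyl for a Nitro on a Weak Binder

The source may hold more compounds than are shown below. What is called first, only, known or untested is meant among the compounds shown, and "the series" means these compounds.

In an assay on cell membranes for binding affinity to adenosine receptor A1 (Bos taurus), read by radioligand binding (on this read-out lower numbers stand for stronger inhibition and higher numbers for weaker inhibition), compound 2 `Cc1cccc(Nc2ncnc3c2nnn3Cc2ccccc2Cl)c1` gives 5880 nM, the highest of the two numbers measured. Among the compounds with values here, compound 1 `CC1CCCC(Nc2ncnc3c2nnn3Cc2ccccc2Cl)C1` gives 102 nM, and the only measured step, a 58-fold higher number from compound 1 to compound 2 (1.76 log units; beyond the scatter), concerns a different part of the molecule. Compound 3 `O=[N+]([O-])c1cccc(Nc2ncnc3c2nnn3Cc2ccccc2Cl)c1` differs from compound 2 by nitro in place of methyl on an aromatic carbon. Within the data shown here, no measured step shows what this swap does on this ring; the expectation rests on compound 2 alone, with wide uncertainty. Compound 3 is expected to give roughly the same number, an estimated 4500 nM within 1000 nM to 20000 nM, meaning the expected step of a 1.3-fold lower number from compound 2 to compound 3 (0.12 log units; within the scatter).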

Compound 3, inhibition constant: 3300 nM
Estimate against measurement, compound 3: 1.4-fold (0.13 log units) above; low and high end bracket the measured number.
By their numbers in this assay, from the lowest: compound 1; then compounds 3 and 2 (each within the scatter of the next).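

In this assay, the swap of nitro for methyl on this aromatic carbon stays small (a 1.8-fold lower number from compound 2 to compound 3 (0.25 log units; within the scatter)), even though the entering group brings two hydrogen-bond acceptors and the leaving one brings none. Neither substituent closes the gap to the 3-methylcyclohexyl compound, as the large step (a 32-fold higher number from compound 1 to compound 3 (1.51 log units; beyond the scatter)) shows. No evidence is available to explain either step. Going by these compounds, whether an amine or a carboxylic acid on this carbon would behave the same way stays open, as does whether any group here could bring a 3-substituted phenyl compound close to compound 1.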